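The compounds below may be only part of what the source reports. "The series", "measured", "known", "first", "only" and "open" are said of these compounds alone.

Measured compounds:
compound 1 `CC(=O)N(/N=N/c1ccc([N+](=O)[O-])cc1)c1ccc([N+](=O)[O-])cc1` — 63000 nM
compound 2 `O=[N+]([O-])c1ccc(/N=N/Nc2ccc([N+](=O)[O-])cc2Br)c(Br)c1` — 940 nM
compound 3 `O=C(c1ccccc1)N(/N=N/c1ccc([N+](=O)[O-])cc1Br)c1ccc([N+](=O)[O-])cc1Br` — 1530 nM

In a functional assay on HeLa cells (Homo sapiens) for cytotoxicity, read by MTT assay, with a stated time of 72 h (on this read-out lower numbers stand for stronger inhibition and higher numbers for weaker inhibition), compound 3 gives 1530 nM, the second highest of the three numbers. Its nearest neighbour is compound 2, and the step of a 1.6-fold higher number from compound 2 to compound 3 (0.21 log units; within the scatter) lies within the scatter, so the two are not distinguished on this read-out. Compound 1, at 63000 nM, stands far above both, well beyond the scatter.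

Compound 4 `O=C(c1ccccc1C(F)(F)F)N(/N=N/c1ccc([N+](=O)[O-])cc1Br)c1ccc([N+](=O)[O-])cc1Br` is the next member. The change from compound 3 is trifluoromethyl in place of hydrogen on an aromatic carbon. Within the data shown here, the only measured step, a 1.6-fold higher number from compound 2 to compound 3 (0.21 log units; within the scatter), concerns the benzoyl entering on the nitrogen and says nothing about a group on that benzoyl's ring; no measured pair varies a substituent there. On this basis the step from compound 3 to compound 4 is expected to be a 1.0-fold lower number from compound 3 to compound 4 (0.01 log units; within the scatter), that is, no change beyond the scatter in this assay. Compound 4 is therefore estimated at 1500 nM, with a range from 500 nM to 4500 nM.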

Compound 4, half-maximal inhibitory concentration: 13300 nM
For compound 4 the middle estimate is 8.9-fold (0.95 log units) below the measured one; the measured number lies above the stated range.
By their numbers in this assay, from the lowest: compounds 2 and 3 (each within the scatter of the next); then compound 4; then compound 1.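

In this assay, trifluoromethyl in place of hydrogen on an aromatic carbon, ortho to a large group, gives an 8.7-fold higher number from compound 3 to compound 4 (0.94 log units; beyond the scatter) and so moves the number beyond the scatter. The ring of the benzoyl is therefore a position that this read-out responds to, which the entry of the benzoyl itself could not show, since a 1.6-fold higher number from compound 2 to compound 3 (0.21 log units; within the scatter) stays within the scatter. This rests on a single pair, and nothing available bears on the reason for the change.

As far as these compounds go, whether the rise belongs to trifluoromethyl specifically or to any group at this carbon remains open; a single fluorine, a methyl, a methoxy or an amine in the same place would separate the two. From the compounds shown here alone, the response at the other carbons of this ring also remains open.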